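From cyclopentyl to phenyl: compound 3 to compound 4

The compounds below may be only part of what the source reports. "The series", "measured", "known", "first", "only" and "open" are said of these compounds alone.

In an ADME assay on microsomes from liver (Homo sapiens) for metabolic stability, read by LC-MS, using NADPH, with a stated time of 45 min, tested at 3 uM (on this read-out lower numbers stand for a shorter-lived compound and higher numbers for a longer-lived compound), compound 1 `C1CCC(C(CC2CCCCN2)C2CC2)CC1` gives 2.07 h. Compound 2 `C1CCC(C(CC2CCCCN2)C2CCC2)CC1` is reported only as a limit, > 3.33 h. Compound 3 `C1CCC(C(CC2CCCCN2)C2CCCC2)CC1` is likewise reported only as a limit, > 2.5 h. No exact number is therefore available as the starting point for the next step.

Compound 4 `c1ccc(C(CC2CCCCN2)C2CCCCC2)cc1` has phenyl in place of cyclopentyl on a saturated chain carbon bound to a saturated chain carbon and a saturated ring carbon.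

Three measured steps change the ring at this same place, but each exchanges one saturated ring for another, so they bear on an aromatic ring only loosely. The first is an at least 1.6-fold higher number from compound 1 to compound 2 (0.20 log units; that floor lies within the scatter). The second is an at least 1.2-fold higher number from compound 1 to compound 3 (0.08 log units; that floor lies within the scatter). The third is a step that the two limits leave unreadable from compound 2 to compound 3.

Resting on an at least 1.2-fold higher number from compound 1 to compound 3 (0.08 log units; that floor lies within the scatter), no step beyond the scatter is expected in this assay, and no direction can be read from these data. The estimate amounts to a number no higher from compound 3 to compound 4 (the limit leaves the size open). The half-life of compound 4 is estimated at 2.5 h, with an expected range from 1.1 h to 5.5 h.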

Compound 4, half-life: 0.933 h
Compound 4: the middle estimate sits 2.7-fold (0.43 log units) above what was measured, and the stated range ends above it.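

In this assay, for the compounds shown here, phenyl on a saturated chain carbon bound to a saturated chain carbon and a saturated ring carbon gives the first steps at this place that are printed as beyond the scatter, and all three go the same way, leaving compound 4 with the shortest half-life of the four: a 2.2-fold lower number from compound 1 to compound 4 (0.35 log units; beyond the scatter), an at least 2.6-fold lower number from compound 3 to compound 4 (0.42 log units; beyond the scatter) and an at least 3.5-fold lower number from compound 2 to compound 4 (0.55 log units; beyond the scatter). Only the first of these has an exact size, and it shows that this place can respond to a change of ring, which the saturated rings alone had not established. Two of the comparisons start from a limit, one for compound 3 and one for compound 2: the limit of > 2.5 h in this assay, at which 1 of the 4 values shown sits.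

Compound 2 is the other compound reported only as a limit: the limit of > 3.33 h in this assay, at which 1 of the 4 values shown sits.

The step between the cyclobutyl and cyclopentyl compounds cannot be read, so no order among the saturated rings can be given. From the compounds shown here alone, whether the drop belongs to aromatic rings in general or to phenyl in particular also stays open, a question that a pyridyl or a fluorophenyl at this place would address.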